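Triazole nitrogen substituent: decyl replaced by phenyl

The compounds below may be only part of what the source reports. "The series", "measured", "known", "first", "only" and "open" are said of these compounds alone.

Measured compounds in a functional assay on THP-1 cells (Homo sapiens) for cytotoxicity, read by MTT assay, with a stated time of 24 h; on this read-out lower numbers stand for stronger inhibition and higher numbers for weaker inhibition:
compound 1 `O=c1c2c(C(F)(F)F)cc(-c3ccccc3)nc2ncn1Cc1cn(CCC(F)(F)C(F)(F)C(F)(F)C(F)(F)C(F)(F)C(F)(F)C(F)(F)C(F)(F)F)nn1`, giving 79.1 ug/mL
compound 2 `CCCCCCCCCCn1cc(Cn2cnc3nc(-c4ccccc4)cc(C(F)(F)F)c3c2=O)nn1`, giving 16.9 ug/mL
compound 3 `CCCCCCCCCCn1cc(Cn2c(C)nc3nc(-c4ccccc4)cc(C(F)(F)F)c3c2=O)nn1`, giving 11.3 ug/mL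

Compound 3 stands at the lowest number of the three, but its nearest neighbour, compound 2, lies within the scatter of it; only compound 1 is clearly apart, its number sitting beyond the scatter above that of compound 3. Compound 4 `Cc1nc2nc(-c3ccccc3)cc(C(F)(F)F)c2c(=O)n1Cc1cn(-c2ccccc2)nn1` has not been measured. Its change from compound 3: phenyl in place of decyl on an aromatic nitrogen. Going by the values given here, no measured step touches this position. Among the compounds with values here, the only measured step, a 1.5-fold lower number from compound 2 to compound 3 (0.17 log units; within the scatter), concerns another position and says nothing about the group on the triazole nitrogen. Within the data shown here, compound 1 and compound 2 differ at that nitrogen, yet no single-point step connects them; their two values show only that the group sitting there can move this assay well beyond the scatter. The direction for a phenyl there cannot be read from the series; a higher number, weaker inhibition, is taken as the more likely outcome, with wide uncertainty. Compound 4 is expected to give 30 ug/mL, between 12 ug/mL and 80 ug/mL. That estimate means an expected step of a 2.7-fold higher number from compound 3 to compound 4 (0.42 log units; beyond the scatter).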

Compound 4, half-maximal inhibitory concentration: > 200 ug/mL
Compound 4: no number, only a limit (the forecaster's own chance of this, stated with the estimate: 10%); middle value at least 6.6-fold (0.82 log units) from the limit.
By their numbers in this assay, from the lowest: compounds 3 and 2 (each within the scatter of the next); then compound 1. At a limit, above all of these: compound 4.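

In this assay compound 4 gives only a limit and not a number: the limit of > 200 ug/mL in this assay, at which 1 of the 4 values shown sits. Going by these compounds alone, the exchange of decyl for phenyl on the aromatic nitrogen, with the shared core untouched, is the first single-change step at this position, and it gives an at least 17-fold higher number from compound 3 to compound 4 (1.24 log units; beyond the scatter). This establishes a direction for this change, towards weaker inhibition, and a step that stands well apart from the methyl step elsewhere on the core, a 1.5-fold lower number from compound 2 to compound 3 (0.17 log units; within the scatter), which stays within the scatter.

The exchange removes a chain and brings in an aromatic ring at once, so the compounds shown do not tell which of the two goes with the higher number. A butyl chain or a benzyl group on the same nitrogen would begin to separate these two parts of the change.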